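Inducible nitric oxide synthase inhibition: ethyl to cyclopropyl

The source may hold more compounds than are shown below. What is called first, only, known or untested is meant among the compounds shown, and "the series" means these compounds.

Measured so far:
compound 1 `COc1ccc(N)c(C2=NN(C(=O)C3CC3)CC2)c1` gives 19.9%
compound 2 `CC(=O)N1CCC(c2ccccc2N)=N1` gives 7.73%
compound 3 `CCC(=O)N1CCC(c2ccccc2N)=N1` gives 6.88%

These three compounds share a core and were tested in an assay on isolated protein for inhibition of Nitric oxide synthase, inducible (Homo sapiens), with a stated time of 30 min, tested at 1 mM; on this read-out lower numbers stand for less inhibition and higher numbers for more inhibition at the one concentration tested (going by the name of the read-out). Compound 3 has the lowest of the three numbers; compound 2 is nearest, within the scatter, while compound 1 stands beyond the scatter above it. Among the measured compounds shown here, the only single-place step available, a number 0.9 percentage points lower from compound 2 to compound 3 (within the scatter), came from putting methyl in place of hydrogen on a saturated chain carbon bound to a carbonyl carbon, and it stayed within the scatter.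

The next compound, compound 4 `Nc1ccccc1C1=NN(C(=O)C2CC2)CC1`, is not yet measured. It differs from compound 3 in one place: cyclopropyl in place of ethyl on a carbonyl carbon.

For the measured compounds named here, the one measured step that bears on a change at this carbonyl carbon was within the scatter, so no step beyond the scatter is expected in this assay either. Going by the values given here, compound 1 also carries cyclopropylcarbonyl, but it differs from compound 4 in a second place as well, so its value shows only that a compound of this kind can sit higher. For compound 4 the expected value is 8%, with a range from 0% to 18%, meaning an expected step of a number 1.1 percentage points higher from compound 3 to compound 4 (within the scatter).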

Compound 4, a percentage reported as inhibition, at one concentration (the size of the read-out at that concentration, not a potency): 14.8%
Compound 4: the middle estimate sits 6.8 percentage points below what was measured; measured number inside the range.
By their numbers in this assay, from the lowest: compounds 3, 2, 4 and 1 (each within the scatter of the next, the first and the last beyond it).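

In this assay, cyclopropyl in place of ethyl on the carbonyl carbon gives a number 7.9 percentage points higher from compound 3 to compound 4 (within the scatter) and cyclopropyl in place of methyl gives a number 7.1 percentage points higher from compound 2 to compound 4 (within the scatter), so a ring at this position has not moved the number beyond the scatter. Among the compounds shown here, compound 4 also allows the methoxy group of compound 1 to be read alone for the first time: hydrogen in its place on an aromatic carbon gives a number 5.1 percentage points lower from compound 1 to compound 4 (within the scatter), so this single change also stays within the scatter. Nothing available here gives a reason for these numbers.

The compounds shown leave open whether a longer chain such as butyl or a larger ring such as cyclohexyl on the carbonyl carbon would give a step beyond the scatter. They also leave open what a hydroxyl or a chlorine in place of methoxy would do.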